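This account rests on a few compounds, and the source may have more. Where it says the series, first, only, none or still open, it means among the compounds named here.

Of the compounds shown here, three built on one shared core have been tested so far in a functional assay on HCT-15 cells (Homo sapiens) for inhibition, read by sulforhodamine B assay, with a stated time of 48 h; a higher number here means a weaker inhibitor of growth, a lower number a stronger inhibitor of growth. Compound 1, `CCOC(=O)[C@H](CCC(=O)O)NC(=O)c1ccc(CNc2nc3cc(N)cc(N)c3nc2-c2ccccc2)cc1`, gives in this assay the value < 100000 nM, which is a limit of the assay rather than a number. Compound 2, `Nc1cc(N)c2nc(-c3ccccc3)c(NCc3ccc(Cl)c(Cl)c3)nc2c1`, likewise gives < 100000 nM, again a limit. Compound 3, `COc1ccc(CNc2nc3cc(N)cc(N)c3nc2-c2ccccc2)cc1OC`, gives < 100000 nM, also a limit. Because of the limit of < 100000 nM in this assay, at which 3 of the 3 values shown sit, the step that the two limits leave unreadable from compound 2 to compound 3 cannot be read, and compound 3 stands only at a limit on the numbers shown, so no ranking among the three is possible. Compound 4, `COc1cc(CNc2nc3cc(N)cc(N)c3nc2-c2ccccc2)cc(OC)c1OC`, differs from compound 3 by methoxy in place of hydrogen on an aromatic carbon. Among the measured compounds shown here, no measured step bears directly on this change, since the single step from compound 2 to compound 3 is unreadable. The expectation for compound 4 in this assay is therefore mostly that it will again sit at the same limit, and the estimated step that the limit leaves unreadable from compound 3 to compound 4 is put near zero. Compound 4 is estimated at 10000 nM, with a range from 1000 nM to 80000 nM.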

Compound 4, concentration for total growth inhibition: 13800 nM
Compound 4: the middle estimate sits 1.4-fold (0.14 log units) below what was measured, and the stated range covers the measured number.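

No size can be read for the change from compound 3 to compound 4, because compound 3 gives only a limit rather than a number: the limit of < 100000 nM in this assay, at which 3 of the 4 values shown sit. From the compounds shown here alone, whether the added methoxy strengthens or weakens growth inhibition in this assay stays open.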